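The source may hold more compounds than are shown below. What is called first, only, known or untested is meant among the compounds shown, and "the series" means these compounds.

The three compounds measured so far, with their results in a functional assay on SK-OV-3 cells (Homo sapiens) for cytotoxicity, read by MTT assay, with a stated time of 48 h; on this read-out higher numbers stand for weaker inhibition and lower numbers for stronger inhibition:

compound 1, `O=C(/C=C/c1ccc2c(c1)B(O)OC2)c1ccccc1`: 3400 nM
compound 2, `O=C(/C=C/c1ccc2c(c1)B(O)OC2)c1cccnc1`: 18500 nM
compound 3, `Cn1cccc1C(=O)/C=C/c1ccc2c(c1)B(O)OC2`: 93600 nM

All three share the same core and differ only in the ring attached to the carbonyl carbon. Compound 3 stands at the top of these numbers, which on this read-out means the weakest inhibition: it lies a 5.1-fold higher number from compound 2 to compound 3 (0.70 log units; beyond the scatter) and a 28-fold higher number from compound 1 to compound 3 (1.44 log units; beyond the scatter).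

Compound 4, `O=C(/C=C/c1ccc2c(c1)B(O)OC2)c1ccc(I)cc1`, is not yet measured. Compared with compound 3 the change is 4-iodophenyl in place of 1-methyl-1H-pyrrol-2-yl on a carbonyl carbon. The step from compound 3 to compound 4 thus returns to a six-membered ring of carbon only, the kind of ring that compound 1 carries, now with an iodine on it.

Among the compounds with values here, the steps that bear on this are the ones that moved away from the carbon-only ring: a 5.4-fold higher number from compound 1 to compound 2 (0.74 log units; beyond the scatter) and a 28-fold higher number from compound 1 to compound 3 (1.44 log units; beyond the scatter), and between the two hetero rings a 5.1-fold higher number from compound 2 to compound 3 (0.70 log units; beyond the scatter). Reversing the largest of these suggests a large fall in the number for compound 4, roughly back to where compound 1 sits; the iodine has no counterpart among the measured compounds, so its own contribution is unknown.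

Compound 4 is therefore expected to give about 4500 nM, within 1500 nM to 15000 nM, an estimated step of a 21-fold lower number from compound 3 to compound 4 (1.32 log units; beyond the scatter).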

Compound 4, half-maximal inhibitory concentration: 4200 nM
The estimate for compound 4 lay 1.1-fold (0.03 log units) above the measured number; the measured number falls inside the stated range.
By their numbers in this assay, from the lowest: compounds 1 and 4 (each within the scatter of the next); then compound 2; then compound 3.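

In this assay, iodo in place of hydrogen on an aromatic carbon is a new kind of change at this position, and it has no readable effect: a 1.2-fold higher number from compound 1 to compound 4 (0.09 log units; within the scatter), so the two compounds cannot be told apart. The other two steps, a 22-fold lower number from compound 3 to compound 4 (1.35 log units; beyond the scatter) and a 4.4-fold lower number from compound 2 to compound 4 (0.64 log units; beyond the scatter), show that the gap between the carbon-only ring and the two hetero rings persists with iodine on the ring. Among these four compounds, phenyl and 4-iodophenyl on the carbonyl carbon both give lower numbers than pyridin-3-yl and 1-methyl-1H-pyrrol-2-yl, with no compound going against this, so replacing the ring moved the number while adding the iodine did not.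

Nothing measured here explains why the type of ring matters or why the iodine leaves the number unmoved. On these data alone, it also remains open whether a different group on the phenyl ring, such as an amine, a carboxylic acid or a methoxy group, would likewise leave the number unmoved.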